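Ethyl versus methyl on the amine in a benzisothiazolone series

The source may report more compounds than this note shows. Statements on the series, on what has been measured and on what is new or still open speak of the compounds shown alone.

Working notes on four amine-bearing analogues sharing one core. Compound 1 `COc1cc2sn(CCCN(C)Cc3ccccc3)c(=O)c2cc1OC` is taken as the starting point. In an assay on isolated protein for inhibition of Amine oxidase [flavin-containing] A (Homo sapiens), read by fluorescence, with a stated time of 30 min (a higher number here means a weaker inhibitor, a lower number a stronger inhibitor), compound 1 gives 6900 nM. Compound 2 `CCN(CCCn1sc2cc(OC)c(OC)cc2c1=O)Cc1ccccc1` carries the change methyl in place of hydrogen on a saturated chain carbon bound to an amine nitrogen and in this assay compound 2 gives 9900 nM. The step of a 1.4-fold higher number from compound 1 to compound 2 (0.16 log units; within the scatter) is small, so these two compounds cannot be told apart on this read-out.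

Compound 3 `COc1cc2sn(CCCCN(C)Cc3ccccc3)c(=O)c2cc1OC` differs from compound 1 in more than one place, and the difference between the two cores is not broken down here. In this assay compound 3 gives 8900 nM, a value that sits with those of compound 1 and compound 2 without any separation beyond the scatter.

Compound 4 `CCN(CCCCn1sc2cc(OC)c(OC)cc2c1=O)Cc1ccccc1` has not yet been measured. Relative to compound 3 it carries the change (methyl in place of hydrogen on a saturated chain carbon bound to an amine nitrogen), which is the same change as that made from compound 1 to compound 2, at the same kind of place. For the measured compounds named here, the only guide to its effect is the single earlier step of a 1.4-fold higher number from compound 1 to compound 2 (0.16 log units; within the scatter), which stayed inside the scatter. On that basis the step of a 1.3-fold higher number from compound 3 to compound 4 (0.13 log units; within the scatter) is expected to be of similar small size, and compound 4 is estimated to give about 12000 nM in this assay, with a plausible range from 6000 nM to 25000 nM because the earlier step of a 1.4-fold higher number from compound 1 to compound 2 (0.16 log units; within the scatter) was small. The measured value for compound 4 follows.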

Compound 4, half-maximal inhibitory concentration: 19900 nM
Estimate against measurement, compound 4: 1.7-fold (0.22 log units) below; the range from low to high includes it.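

In this assay, methyl in place of hydrogen on a saturated chain carbon bound to an amine nitrogen, which reads as methyl to ethyl on the amine, gives a 2.2-fold higher number from compound 3 to compound 4 (0.35 log units; beyond the scatter), a modest step. Set beside the same change on the other core, this step cannot be told apart from the earlier one: the same change on two cores in this assay, a 1.4-fold higher number (0.16 log units; within the scatter) from compound 1 to compound 2 and a 2.2-fold higher number (0.35 log units; beyond the scatter) from compound 3 to compound 4, 1.6-fold (0.19 log units) apart, within the scatter of two such steps The change therefore carries from one core to the other with no size difference that can be resolved, but this rests on a single pair of steps, only one of which lies beyond the scatter, so it does not establish a general penalty for ethyl on the amine or show that the core has no influence on the step.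

Still open, from the compounds shown here alone, is whether a larger group on the amine nitrogen, such as propyl or isopropyl, would extend the step seen with ethyl or leave the numbers within the scatter. Also open is whether the same change would behave alike with a longer chain joining the shared core to the amine, since the two cores shown give only two points for comparison.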